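The source may hold more compounds than are shown below. What is called first, only, known or untested is meant among the compounds shown, and "the series" means these compounds.

Compound 1 `Cn1c(=O)c(S(=O)(=O)c2ccc(F)cc2F)cc2cnc(Nc3ccncn3)nc21` and compound 2 `Cn1c(=O)c(S(=O)(=O)c2ccc(F)cc2F)cc2cnc(Nc3cnc4[nH]ccc4c3)nc21` share one core and differ only in the group on a nitrogen on an aromatic ring. In a functional assay on K562 cells (Homo sapiens) for inhibition, read by trypan blue exclusion, with a stated time of 72 h (on this read-out higher numbers stand for weaker inhibition and lower numbers for stronger inhibition), compound 1 gives 30000 nM, while compound 2 gives 750 nM. Among the compounds with values here, compound 2 therefore holds the lower of the two numbers so far, meaning the stronger inhibition.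

Compound 3 `Cn1c(=O)c(S(=O)(=O)c2ccc(F)cc2F)cc2cnc(Nc3ccc4cccc(O)c4n3)nc21` keeps the same core but carries 8-hydroxyquinolin-2-yl at that nitrogen, and the change is a group of 11 heavy atoms (9 carbon, 1 nitrogen, 1 oxygen; one six-membered aromatic ring of carbon only, one six-membered aromatic ring with 1 hetero atom) in place of a group of 9 heavy atoms (7 carbon, 2 nitrogen; one five-membered aromatic ring with 1 hetero atom, one six-membered aromatic ring with 1 hetero atom), on a nitrogen on an aromatic ring. Within the data shown here, only one measured step bears on this swap, and it sits at the same place: a 40-fold lower number from compound 1 to compound 2 (1.60 log units; beyond the scatter). That large step shows that a change of group here can move the number well beyond the scatter in this assay. It does not show which way a new group will push it. The leaving and entering groups each hold a six-membered aromatic ring with 1 hetero atom, so no clear direction can be argued from the data. The expected result is therefore little net movement, an estimated 1.3-fold lower number from compound 2 to compound 3 (0.10 log units; within the scatter), with wide uncertainty. For compound 3 the estimated value is 600 nM, with an expected range from 80 nM to 5000 nM.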

Compound 3, half-maximal inhibitory concentration: 5000 nM
Compound 3: middle estimate off by 8.3-fold (0.92 log units), on the low side, within the range that was stated.
By their numbers in this assay, from the lowest: compound 2; then compound 3; then compound 1.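

In this assay, putting 8-hydroxyquinolin-2-yl on this nitrogen gives a 6.7-fold higher number from compound 2 to compound 3 (0.82 log units; beyond the scatter) and so loses part of what the earlier step gained, even though the leaving and entering groups each hold a six-membered aromatic ring with 1 hetero atom and a hydrogen-bond donor. The same group still gives a 6.0-fold lower number from compound 1 to compound 3 (0.78 log units; beyond the scatter) and so keeps part of that gain, which places compound 3 between the other two on this read-out. The number at this position therefore does not simply follow group size, as compound 3 carries the group with the most heavy atoms yet compound 2 holds the lowest number, and nothing shown gives a reason for these differences.

On these data alone, what the hydroxy group itself contributes remains open, as the effect of 8-hydroxyquinolin-2-yl can be read only for the group as a whole. Also open, as far as these compounds go, is how the number would respond to a phenyl ring carrying an amine or a carboxylic acid at this nitrogen, or to a simple alkyl chain there.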